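The source may hold more compounds than are shown below. What is called first, only, known or untested is meant among the compounds shown, and "the series" means these compounds.

Compound 1 `Clc1ccc2c(O/N=C(/C=C/c3ccc(OCc4ccccc4Cl)cc3)\C=C\c3ccccn3)ncnc2c1` is the weakest of the three measured compounds in a functional assay on SMMC-7721 cells (Homo sapiens) for inhibition, read by MTT assay, with a stated time of 72 h, tested at 1 uM; a higher number here means a stronger effect of the compound at the concentration tested, a lower number a weaker effect: compound 1 gives 18.1%. Compound 2 `Clc1ccc(COc2ccc(/C=C/C(/C=C/c3ccccn3)=N/Oc3ncnc4cc(Cl)ccc34)cc2)cc1` gives 67.4%, and compound 3 `Fc1ccccc1COc1ccc(/C=C/C(/C=C/c2ccccn2)=N/Oc2ncnc3cc(Cl)ccc23)cc1` gives 81.1%. The measured steps among these three all concern the group on the saturated chain carbon bound to an oxygen on an aromatic ring: a number 49.3 percentage points higher from compound 1 to compound 2 (beyond the scatter), a number 63 percentage points higher from compound 1 to compound 3 (beyond the scatter), and a number 13.7 percentage points higher from compound 2 to compound 3 (beyond the scatter). Compound 4 `Clc1ccccc1COc1ccc(/C=C/C(/C=C/c2ccccn2)=N/Oc2ncnc3ccccc23)cc1` differs from compound 1 elsewhere, at the shared core: hydrogen in place of chloro on an aromatic carbon, which read one bond further out is 7-chloroquinazolin-4-yl to quinazolin-4-yl. For the measured compounds named here, none of the measured steps touches that place, so no measured step bears on this change, and the size of its effect in this assay cannot be read from compounds 1, 2 and 3. Lacking any guidance, the step expected is a number 1.9 percentage points higher from compound 1 to compound 4 (within the scatter), that is, nothing clearly beyond the scatter in either direction, with a wide allowance for the unknown. Compound 4 is accordingly estimated in this assay at 20%, within a range from 3% to 50%.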

Compound 4, a percentage reported as inhibition, at one concentration (the size of the read-out at that concentration, not a potency): 10.1%
Compound 4: middle estimate off by 9.9 percentage points, on the high side; low and high end bracket the measured number.
By their numbers in this assay, from the lowest: compounds 4 and 1 (each within the scatter of the next); then compound 2; then compound 3.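

At the shared core, hydrogen in place of chloro on an aromatic carbon, read further out as 7-chloroquinazolin-4-yl to quinazolin-4-yl, gives a number 8 percentage points lower from compound 1 to compound 4 (within the scatter) in this assay. For the compounds shown here, this is the first reading at this place, and with the 2-chlorophenyl group held fixed, the chloro shows no effect that can be told from the scatter, unlike the changes at the far end of the molecule. No measurement at hand offers an explanation for this result.

The compounds shown leave open whether this change would also stay within the scatter alongside the 4-chlorophenyl of compound 2 or the 2-fluorophenyl of compound 3. They also leave open how a methoxy group or an amine would read on this aromatic carbon.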